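The source may report more compounds than this note shows. Statements on the series, on what has been measured and on what is new or still open speak of the compounds shown alone.

Measured compounds:
compound 1, `Cc1ccc(C(=O)CC(=O)OC(C)Cn2cnc3c2c(=O)n(C)c(=O)n3C)cc1`: 89%
compound 2, `CC(Cn1cnc2c1c(=O)n(C)c(=O)n2C)OCc1cn(CCCn2cnc3c(Br)c(Br)c(Br)c(Br)c32)nn1`: 74.5%
compound 3, `CC(Cn1cnc2c1c(=O)n(C)c(=O)n2C)OCc1cn(-c2cccc3ccccc23)nn1`: 93.5%

In a functional assay on MCF7 cells (Homo sapiens) for antiproliferative activity, read by MTT assay, with a stated time of 72 h, tested at 25 uM (a lower number here means a stronger effect, a higher number a weaker effect of the compound at the concentration tested), compound 1 gives 89%. Among the three numbers this is the second highest. Compound 3 gives 93.5%, a number within the usual scatter of that of compound 1, so the two cannot be told apart. Compound 2 gives 74.5%, a number lower than that of compound 1 by more than the scatter, so compound 2 shows the stronger effect of the two.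

The unmeasured compound 4, `CC(Cn1cnc2c1c(=O)n(C)c(=O)n2C)OC(=O)CC(=O)c1ccc(F)cc1`, differs from compound 1 in one place: fluoro in place of methyl on an aromatic carbon. One atom is swapped for another on an aromatic carbon of a six-membered aromatic ring of carbon only, para to a large group; no ring and no hydrogen-bond donor or acceptor is lost or gained. Going by the values given here, no measured pair shows this kind of change, so its effect in this assay is not known from the data. A small step is expected, if any, in either direction and not beyond the scatter. Compound 4 is expected to give 87%, in the range 72% to 100%. The step of a number 2 percentage points lower from compound 1 to compound 4 (within the scatter) is expected to stay within the scatter.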

Compound 4, a percentage reported as activity, at one concentration (the size of the read-out at that concentration, not a potency): 88.5%
Compound 4: middle estimate off by 1.5 percentage points, on the low side, and the stated range covers the measured number.
By their numbers in this assay, from the lowest: compound 2; then compounds 4, 1 and 3 (each within the scatter of the next).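

In this assay, putting fluoro in place of methyl gives a number 0.5 percentage points lower from compound 1 to compound 4 (within the scatter), so this first pair differing in one place shows no change that can be told from scatter. For this one pair, then, the aromatic carbon para to a large group takes either a 4-methylphenyl or a 4-fluorophenyl arrangement with no visible difference in the read-out. No measurement on hand speaks to why the two compounds read alike.

As far as these compounds go, one swap between two small groups says little about how much this position can tolerate, so it remains open whether an amine, a carboxylic acid or a longer chain on the same carbon would move the number. Also open, from the compounds shown here alone, is whether the same fluoro for methyl swap would read alike on a different core.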